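The source may report more compounds than this note shows. Statements on the series, on what has been measured and on what is new or still open speak of the compounds shown alone.

Working notes on the series. Compound 1 `CN(C)c1ccc(/C=C2/SC(=Nc3ccc(O)cc3)NC2=O)cc1` is the weaker of the two measured compounds in a functional assay on NCI-H460 cells (Homo sapiens) for antiproliferative activity; on this read-out lower numbers stand for stronger inhibition and higher numbers for weaker inhibition: compound 1 gives 1320 nM, while compound 2 `Cc1ccccc1/N=C1\NC(=O)/C(=C\c2ccc(N(C)C)cc2)S1` gives 650 nM, a gap that lies beyond the usual scatter. The two differ in more than one place, so their values are set side by side without a computed step.

Compound 3 `CN(C)c1ccc(/C=C2/SC(=Nc3ccccc3Cl)NC2=O)cc1` departs from compound 1 at the aryl group on the double-bonded nitrogen: 2-chlorophenyl in place of 4-hydroxyphenyl on a double-bonded nitrogen. Compound 2 carries a substituted phenyl on the same nitrogen and, with 650 nM, sits at the lower end of the measured range, so a modest move toward lower numbers is expected for this step, of a size that may not clear the scatter. The step from compound 1 to compound 3 is estimated at a 1.8-fold lower number from compound 1 to compound 3 (0.25 log units; within the scatter). For compound 3 in this assay the expected value is 750 nM, with a range from 300 nM to 1800 nM.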

Compound 3, half-maximal inhibitory concentration: 730 nM
Beside the measured number, compound 3's estimate is 1.0-fold (0.01 log units) above it; low and high end bracket the measured number.
By their numbers in this assay, from the lowest: compounds 2, 3 and 1 (each within the scatter of the next, the first and the last beyond it).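

In this assay, the aryl group on the double-bonded nitrogen can be exchanged, 2-chlorophenyl in place of 4-hydroxyphenyl, with a 1.8-fold lower number from compound 1 to compound 3 (0.26 log units; within the scatter). For the compounds shown here, this is the first step that changes a single place, and it shows that the hydrogen-bond donor and acceptor counted on the leaving 4-hydroxyphenyl can go, and a chlorine come in, without a shift beyond the scatter at this position. Nothing at hand gives a reason for this result or ties it to a property of either group.

This step changes both the substituent and where it sits on the phenyl ring, so 4-chlorophenyl or 2-hydroxyphenyl would be needed to separate the two. Also open, on these data alone, is how this position responds to a different kind of group, such as an amine, a carboxylic acid or a longer alkyl chain.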